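This account rests on a few compounds, and the source may have more. Where it says the series, first, only, none or still open, it means among the compounds named here.

In a functional assay on SK-BR-3 cells (Homo sapiens) for antiproliferative activity (on this read-out higher numbers stand for weaker inhibition and lower numbers for stronger inhibition), compound 1 `C#CCOc1ccc(C(=O)Nc2cc3ccc(OC4CCN(C)CC4)c(C)c3oc2=O)cc1CC=C(C)C` gives 1400 nM, compound 2 `C=CCc1cc(C(=O)Nc2cc3ccc(OC4CCN(C)CC4)c(C)c3oc2=O)ccc1OC(C)=O` gives 2260 nM and compound 3 `CC(C)=CCc1cccc(C(=O)Nc2cc3ccc(OC4CCN(C)CC4)c(C)c3oc2=O)c1` gives 1680 nM. Compound 3 thus stands within the scatter of both others, and the three numbers are not separated. Compound 4 `C=CCc1cc(C(=O)Nc2cc3ccc(OC4CCN(C)CC4)c(C)c3oc2=O)ccc1O` has 3-allyl-4-hydroxyphenyl in place of 3-(3-methylbut-2-en-1-yl)phenyl on a carbonyl carbon. Going by the values given here, the only measured step with bearing on this change, a 1.2-fold higher number from compound 1 to compound 3 (0.08 log units; within the scatter), stays within the scatter, though it covers a different group. Compound 2 also carries an allyl chain, and its value sits with the others. No shift beyond the scatter is expected, in either direction, an estimated 1.2-fold higher number from compound 3 to compound 4 (0.08 log units; within the scatter). For compound 4 the expected value is 2000 nM, with an estimated range of 900 nM to 4500 nM.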

Compound 4, half-maximal inhibitory concentration: 2430 nM
Compound 4: middle estimate off by 1.2-fold (0.08 log units), on the low side, within the range that was stated.
By their numbers in this assay, from the lowest: compounds 1, 3, 2 and 4 (each within the scatter of the next).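

On the carbonyl carbon, 3-allyl-4-hydroxyphenyl in place of 3-(3-methylbut-2-en-1-yl)phenyl gives a 1.4-fold higher number from compound 3 to compound 4 (0.16 log units; within the scatter) in this assay and so does not separate the two compounds, even with the shorter chain and the added hydrogen-bond donor. Hydrogen in place of acetyl on the aromatic oxygen gives a 1.1-fold higher number from compound 2 to compound 4 (0.03 log units; within the scatter) and leaves that oxygen's substituent equally unresolved. No evidence on hand bears on these results.

The separate contributions of the chain and the hydroxyl remain unresolved in the step between compound 3 and compound 4. From the compounds shown here alone, whether an amine or a carboxylic acid on the phenyl would move the number beyond the scatter stays open.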